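This account rests on a few compounds, and the source may have more. Where it says the series, first, only, none or still open, it means among the compounds named here.

Measured so far:
Compound 2, `COc1cc(N(Cc2nc3ccccc3[nH]2)S(=O)(=O)c2ccc(C)cc2)cc(OC)c1OC`: in a functional assay on PC-3 cells (Homo sapiens) for inhibition, read by MTT assay, with a stated time of 48 h (on this read-out higher numbers stand for weaker inhibition and lower numbers for stronger inhibition), compound 2 gives 3340 nM.
Compound 1, `COc1ccc(CN(c2cc(OC)c(OC)c(OC)c2)S(=O)(=O)c2ccccc2)cc1`: in this assay compound 1 gives only a limit, > 50000 nM.

Going by the values given here, compound 2 thus holds the only real number here; the other entry sits at the limit of the assay (the limit of > 50000 nM in this assay, at which 1 of the 2 values shown sits). Compound 3, `COc1cc(N(Cc2nc3ccccc3[nH]2)S(=O)(=O)c2ccccc2)cc(OC)c1OC`, differs from compound 2 in one place: hydrogen in place of methyl on an aromatic carbon, in words, hydrogen in place of methyl on an aromatic carbon. Among the compounds with values here, no measured pair shows such a change, so a step of no clear direction is expected, not beyond the usual scatter. Compound 3 is estimated to give 4500 nM, between 1500 nM and 15000 nM. The expected step is a 1.3-fold higher number from compound 2 to compound 3 (0.13 log units; within the scatter).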

Compound 3, half-maximal inhibitory concentration: 25500 nM
The estimate for compound 3 lay 5.7-fold (0.75 log units) below the measured number; the measured number lies above the stated range.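

Going from 4-methylphenyl to phenyl shows that this single methyl matters in this assay: the change gives a 7.6-fold higher number from compound 2 to compound 3 (0.88 log units; beyond the scatter) and so costs clear strength. Placing 1H-benzimidazol-2-yl in the position of 4-methoxyphenyl gives an at least 1.9-fold lower number from compound 1 to compound 3 (0.29 log units; that floor lies within the scatter) and this floor alone shows no clear gain. Compound 1 gives a limit, not a number: the limit of > 50000 nM in this assay, at which 1 of the 3 values shown sits.

These values do not tell why the methyl matters. On these data alone, whether an ethyl group, a chlorine atom or a methoxy group in its place would match compound 2 remains open.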